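Working notes: cytotoxicity across a small series

The source may report more compounds than this note shows. Statements on the series, on what has been measured and on what is new or still open speak of the compounds shown alone.

Measured so far in an ADME assay on HepG2 cells (Homo sapiens) for cytotoxicity, read by luminescence, CellTiter-Glo and ATP content, with a stated time of 72 h; a higher number here means that more compound is needed for the effect, a lower number that less compound is needed:
compound 1 `COc1ccc(F)cc1CNCCCNc1ccnc2cc(Oc3ccc(F)cc3)ccc12` gives 6600 nM
compound 2 `COc1cccc(CNCCCNc2ccnc3cc(-c4ccc(C(C)(C)C)cc4)ccc23)c1O` gives 690 nM
compound 3 `COc1ccc(F)cc1CNCCCNc1ccnc2cc(Cc3cccc(C(F)(F)F)c3)ccc12` gives 440 nM

Compound 3 carries the lowest of the three numbers; compound 2 sits near it, within the scatter, while compound 1 lies far from it. Within the data shown here, the only measured step, a 15-fold lower number from compound 1 to compound 3 (1.18 log units; beyond the scatter), is large. Compound 4 `COc1ccc(F)cc1CNCCCNc1ccnc2cc(-c3ccc(C(C)(C)C)cc3)ccc12` comes next: 4-(tert-butyl)phenyl in place of 3-(trifluoromethyl)benzyl on an aromatic carbon. Among the measured compounds shown here, no measured step covers this exact change, but compound 2 bears the same entering group and its value sits close to that of compound 3, so in this assay no movement beyond the scatter is expected, perhaps a slightly higher number. Compound 4 is therefore estimated at 750 nM, within 300 nM to 1900 nM, an expected step of a 1.7-fold higher number from compound 3 to compound 4 (0.23 log units; within the scatter).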

Compound 4, half-maximal effective concentration: 620 nM
Estimate against measurement, compound 4: 1.2-fold (0.08 log units) above; measured number inside the range.
By their numbers in this assay, from the lowest: compounds 3, 4 and 2 (each within the scatter of the next); then compound 1.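

In this assay, 4-(tert-butyl)phenyl and 3-(trifluoromethyl)benzyl on this aromatic carbon cannot be told apart (a 1.4-fold higher number from compound 3 to compound 4 (0.15 log units; within the scatter)), whereas 4-fluorophenoxy stands well apart from 4-(tert-butyl)phenyl (an 11-fold lower number from compound 1 to compound 4 (1.03 log units; beyond the scatter)). The change to 5-fluoro-2-methoxyphenyl from 2-hydroxy-3-methoxyphenyl on the saturated chain carbon also stays within the scatter (a 1.1-fold lower number from compound 2 to compound 4 (0.05 log units; within the scatter)). No available evidence accounts for these steps.

Still open, on these data alone, is whether a morpholine or a carboxylic acid on this aromatic carbon would give a number nearer that of compound 1 or that of compound 4.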